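Adding a Second Methyl to an Indole Diterpenoid Ester

The compounds below may be only part of what the source reports. "The series", "measured", "known", "first", "only" and "open" are said of these compounds alone.

Compound 1 `COC(=O)[C@@]1(C)CCC=C2[C@@H]1CC[C@@H](C)[C@]2(C)Cc1c[nH]c2ccc(C)cc12` and compound 2 `COC(=O)[C@@]1(C)CCC=C2[C@@H]1CC[C@@H](C)[C@]2(C)Cc1c(C)[nH]c2ccccc12` share one core and differ only in where a single methyl sits. In a functional assay on T47D cells (Homo sapiens) for inhibition, read by sulforhodamine B assay, with a stated time of 48 h (a lower number here means a stronger inhibitor of growth, a higher number a weaker inhibitor of growth), compound 1 gives 20000 nM and compound 2 gives 17000 nM; the two numbers lie within the usual scatter, so compound 2 stands level with compound 1 rather than apart from it. Compound 3 `COC(=O)[C@@]1(C)CCC=C2[C@@H]1CC[C@@H](C)[C@]2(C)Cc1c(C)[nH]c2ccc(C)cc12` carries both methyls, arising from compound 2 by methyl in place of hydrogen on an aromatic carbon. Among the measured compounds shown here, no measured pair shows such a step, so nothing beyond the scatter is expected in this assay. Compound 3 is therefore estimated at 15000 nM, within 6000 nM to 40000 nM, a step of a 1.1-fold lower number from compound 2 to compound 3 (0.05 log units; within the scatter) expected to stay inside the scatter.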

Compound 3, concentration for 50% growth inhibition: 31000 nM
Compound 3: middle estimate off by 2.1-fold (0.32 log units), on the low side, and the stated range covers the measured number.
By their numbers in this assay, from the lowest: compounds 2, 1 and 3 (each within the scatter of the next).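

In this assay, methyl in place of hydrogen on an aromatic carbon of the six-membered aromatic ring gives the first reading of this change (a 1.8-fold higher number from compound 2 to compound 3 (0.26 log units; within the scatter)), and the second listed reading of the same change stays equally small (a 1.6-fold higher number from compound 1 to compound 3 (0.19 log units; within the scatter)). Compound 3, with both methyls, thus stands level with compound 1 and compound 2, each with one methyl. No evidence at hand bears on this result. The compounds shown leave open whether an amine, a carboxylic acid or a longer chain on this aromatic carbon would move the number beyond the scatter.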